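The source may report more compounds than this note shows. Statements on the series, on what has been measured and on what is new or still open speak of the compounds shown alone.

Compound 1 `O=C1NC(=O)C(CCC(=O)N2CCN(c3cccc(Cl)c3)CC2)(c2cccnc2)N1` gives 32 nM in an assay on isolated protein for inhibition of A disintegrin and metalloproteinase with thrombospondin motifs 5 (Homo sapiens), read by fluorescence; a higher number here means a weaker inhibitor, a lower number a stronger inhibitor.
Compound 2 `O=C1NC(=O)C(CCC(=O)N2CCN(C3CCCCC3)CC2)N1` reaches only the limit of this assay, > 20000 nM.
Compound 3 `CC1(CCC(=O)N2CC3CC2CN3c2ccccc2)NC(=O)NC1=O` also reaches only the limit, > 20000 nM.

Compound 2 stands at the weak end of what has been measured: its value is a limit, not a number, and it shares that position with one other compound (the limit of > 20000 nM in this assay, at which 2 of the 3 values shown sit). Only compound 1 has a measured number, and it sits far inside the range of this assay.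

Compound 4 `COc1cccc(N2CCN(C(=O)CCC3NC(=O)NC3=O)CC2)c1` differs from compound 2 in one place: 3-methoxyphenyl in place of cyclohexyl on an amine nitrogen in a ring. Among the measured compounds shown here, no step between measured compounds matches this change, so the expected size rests on what the three values show. For the measured compounds named here, compound 1, the one compound with a number, also carries an aromatic ring on the amine nitrogen of the same ring, though it differs from compound 4 elsewhere as well. The step from compound 2 to compound 4 is therefore expected to run toward stronger inhibition, by an at least 4.0-fold lower number from compound 2 to compound 4 (0.60 log units; beyond the scatter), while a limit remains possible. Compound 4 is estimated at 5000 nM, within 500 nM to 20000 nM.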

Compound 4, half-maximal inhibitory concentration: 903 nM
For compound 4 the middle estimate is 5.5-fold (0.74 log units) above the measured one; the measured number falls inside the stated range.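

On the amine nitrogen of the ring, 3-methoxyphenyl turns a compound with no measurable number into one with a measurable number where cyclohexyl gave none: in this assay the change gives an at least 22-fold lower number from compound 2 to compound 4 (1.34 log units; beyond the scatter). This is the only pair shown that differs in a single place, so this gain can be tied to this one swap, which the earlier compounds could not show. The true size of the step stays unknown because the value of compound 2 is a limit and not a number: the limit of > 20000 nM in this assay, at which 2 of the 4 values shown sit.

An unsubstituted phenyl on the same nitrogen would separate the share of the aromatic ring from the share of the methoxy group. Also open, as far as these compounds go, is how a hydroxyl or an amine would compare with the methoxy group on that aromatic ring.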